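Hydroxy in place of phenyl on a chalcone-type scaffold

A few compounds are considered here, and "the series" means these few. Any claim that something is new, unique, unknown or untested is made for them only; others in the source may bear on it.

The shared core carries a propenone chain that ends in an aromatic ring, and the compounds differ only in that ring. Compound 1 `COc1ccc(C(=O)/C=C/c2ccc(-c3ccccc3)cc2)c2c1C=CC(C)(C)O2` bears a phenyl on it; in a functional assay on SW-620 cells (Homo sapiens) for antiproliferative activity, read by MTT assay, with a stated time of 24 h (a lower number here means a stronger inhibitor, a higher number a weaker inhibitor), compound 1 gives > 10000 nM, which is a limit of the assay rather than a number, so it stands at the limit of > 10000 nM in this assay, at which 1 of the 3 values shown sits. Compound 2 `COc1ccc(C(=O)/C=C/c2cccc([N+](=O)[O-])c2)c2c1C=CC(C)(C)O2` gives 4090 nM in this assay, and compound 3 `COc1ccc(C(=O)/C=C/c2ccccn2)c2c1C=CC(C)(C)O2` gives 5000 nM. For the measured compounds named here, the only measured step, a 1.2-fold higher number from compound 2 to compound 3 (0.09 log units; within the scatter), exchanges the whole aryl group and does not touch the change considered here.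

Compound 4 `COc1ccc(C(=O)/C=C/c2ccc(O)cc2)c2c1C=CC(C)(C)O2` carries the change (hydroxy in place of phenyl on an aromatic carbon). Going by the values given here, no measured step bears on a hydroxy at this place, and compound 1 offers only a limit, so the direction of an at least 1.4-fold lower number from compound 1 to compound 4 (0.15 log units; that floor lies within the scatter) is expected mainly from where compound 2 and compound 3 sit, with wide uncertainty. Compound 4 is therefore estimated at 7000 nM, in the range 2000 nM to 25000 nM, with a real chance that this assay again reports only a limit.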

Compound 4, half-maximal inhibitory concentration: > 10000 nM
Compound 4: a limit, no number; the forecaster's own chance of this, stated with the estimate: 40%; middle value at least 1.4-fold (0.15 log units) from the limit.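

With hydroxy in place of phenyl, compound 4 joins compound 1 at the limit of this assay, so the step between them cannot be read: the limit of > 10000 nM in this assay, at which 2 of the 4 values shown sit.

Against the other two compounds the result gives an at least 2.0-fold higher number from compound 3 to compound 4 (0.30 log units; that floor lies within the scatter), and an at least 2.4-fold higher number from compound 2 to compound 4 (0.38 log units; beyond the scatter). A group on this aromatic carbon, para to a large group, has now given a limit twice, once as phenyl and once as hydroxy, whereas the two numbers in this set come from the 3-nitrophenyl and pyridin-2-yl compounds.

From the compounds shown here alone, how far either limit lies from a true number stays open, and so does whether phenyl and hydroxy differ at all at this place. Going by these compounds, it is also open whether an amine or a carboxylic acid on this carbon would bring a number back into range.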